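Trading an Unsaturated Acyl Group for a Saturated One

The source may report more compounds than this note shows. Statements on the series, on what has been measured and on what is new or still open speak of the compounds shown alone.

Measured compounds:
- compound 1, `C/C=C/C(=O)N(Cc1ccc(OC)c(OC)c1)c1cc(OC)c(OC)c(OC)c1`: 20100 nM
- compound 2, `C=C(C)C(=O)N(Cc1ccc(OC)c(O)c1)c1cc(OC)c(OC)c(OC)c1`: 390 nM
- compound 3, `C/C=C/C(=O)N(Cc1cccc(O)c1)c1cc(OC)c(OC)c(OC)c1`: 14100 nM

All three were tested in a functional assay on MGC-803 cells (Homo sapiens) for inhibition, read by MTT assay, with a stated time of 48 h; on this read-out higher numbers stand for weaker inhibition and lower numbers for stronger inhibition. Compound 2 gives 390 nM, the lowest number of the three and therefore the strongest inhibition here; the gaps to compound 3 at 14100 nM and to compound 1 at 20100 nM both lie beyond the scatter. Compounds 1 and 3 differ from compound 2 in more than one place, so their values say only that they inhibit more weakly, not which change is responsible.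

Compound 4, `COc1ccc(CN(C(=O)C(C)C)c2cc(OC)c(OC)c(OC)c2)cc1O`, has not yet been measured in this assay. It differs from compound 2 in one place: isopropyl in place of 1-methylethenyl on a carbonyl carbon. Among the compounds with values here, no pair of measured compounds shows this kind of change, so its effect is unknown. The expectation is a moderate weakening, a step from compound 2 to compound 4 of a 3.8-fold higher number from compound 2 to compound 4 (0.59 log units; beyond the scatter), though a step within the scatter cannot be ruled out. Compound 4 is therefore estimated at 1500 nM, with a range from 300 nM to 8000 nM.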

Compound 4, half-maximal inhibitory concentration: 210 nM
Beside the measured number, compound 4's estimate is 7.1-fold (0.85 log units) above it, and the stated range ends above it.
By their numbers in this assay, from the lowest: compounds 4 and 2 (each within the scatter of the next); then compounds 3 and 1 (each within the scatter of the next).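

With isopropyl in place of 1-methylethenyl on a carbonyl carbon, this assay gives a 1.9-fold lower number from compound 2 to compound 4 (0.27 log units; within the scatter). This is the first single-place change shown at this position, and it indicates that the double bond of 1-methylethenyl is not required for inhibition at the level of compound 2, since the saturated group of the same size in heavy atoms reads the same within the scatter. Nothing measured here explains why the two groups read alike.

As far as these compounds go, whether the carbonyl carbon tolerates very different groups, such as a longer chain, a cyclohexyl ring or an amine, remains open. Compound 1 and compound 3 each differ from compound 2 in more than one place, so what their own acyl group contributes cannot yet be read.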